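A pentan-3-yl group replaces an aryloxy group

The compounds below may be only part of what the source reports. "The series", "measured", "known", "first", "only" and "open" are said of these compounds alone.

- compound 1 `COc1cccc(CNCCCNc2ccnc3cc(Cc4ccc(F)cc4)ccc23)c1O`: 23 10^-6 cm/s
- compound 2 `COc1ccc(Oc2ccc3c(NCCCNCc4cccc(OC)c4O)ccnc3c2)cc1`: 317 10^-6 cm/s
- compound 3 `COc1cccc(CNCCCNc2ccnc3cc(Oc4cccc(N(C)C)c4)ccc23)c1O`: 317 10^-6 cm/s

These values come from an ADME assay for permeability, using PAMPA, with a stated time of 30 min, at pH 7.4; on this read-out higher numbers stand for higher permeability and lower numbers for lower permeability. Compound 3 stands level with compound 2, and the two share the top of this small set, well clear of compound 1. Compound 4 `CCC(CC)c1ccc2c(NCCCNCc3cccc(OC)c3O)ccnc2c1` has not yet been measured. It differs from compound 3 by pentan-3-yl in place of 3-(dimethylamino)phenoxy on an aromatic carbon.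

Two measured steps change that same aromatic carbon, a 14-fold higher number from compound 1 to compound 2 (1.14 log units; beyond the scatter) and a 14-fold higher number from compound 1 to compound 3 (1.14 log units; beyond the scatter). Both are large, so a change at this place has already moved the read-out well beyond the scatter. A third step, no change at the digits printed from compound 2 to compound 3 (within the scatter), changes only the group on the oxygen and leaves the number where it was. Compound 4 loses the phenoxy group that compound 2 and compound 3 share, as compound 1 also lacks it. Going by the values given here, no measured compound carries pentan-3-yl, so the data do not fix how far the number will move.

A moderate fall is expected, with the estimated step being a 3.5-fold lower number from compound 3 to compound 4 (0.55 log units; beyond the scatter). For compound 4 the estimated value is 90 10^-6 cm/s, with an expected range from 25 10^-6 cm/s to 320 10^-6 cm/s.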

Compound 4, apparent permeability: 23 10^-6 cm/s
Compound 4: the middle estimate sits 3.9-fold (0.59 log units) above what was measured; measured number outside the range, below it.
By their numbers in this assay, from the lowest: compounds 1 and 4 (each within the scatter of the next); then compounds 2 and 3 (each within the scatter of the next).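

In this assay, pentan-3-yl gives a 14-fold lower number from compound 3 to compound 4 (1.14 log units; beyond the scatter) and a 14-fold lower number from compound 2 to compound 4 (1.14 log units; beyond the scatter), so the high numbers of the two aryloxy compounds do not carry over to this group without a ring. Going by these compounds alone, the step to the other low compound is no change at the digits printed from compound 1 to compound 4 (within the scatter), which shows that pentan-3-yl and 4-fluorobenzyl cannot be told apart here even though only 4-fluorobenzyl carries a ring, so a ring on this aromatic carbon does not by itself go with the higher numbers; across these four compounds, the two groups joined through oxygen give the high numbers and the two joined through carbon give the low numbers, with no compound going against that split. Nothing at hand gives a reason for this split.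

The compounds shown leave open whether the oxygen link alone goes with the higher numbers or whether it needs the aryl ring beyond it. A methoxy group on this carbon has the oxygen without the aryl ring, and a phenylamino group has the aryl ring with a nitrogen link, so these two would pull the link and the ring apart.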